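A few compounds are considered here, and "the series" means these few. Any claim that something is new, unique, unknown or untested is made for them only; others in the source may bear on it.

Compound 2, `CN(C)CCn1cnnc1-c1cc(Oc2ccc(NC(=O)N/N=C/c3ccc(F)cc3Cl)cc2F)ccn1` — 720 nM
Compound 1, `CN(C)CCn1cnnc1-c1cc(Oc2ccc(NC(=O)N/N=C/c3ccc(O)cc3)cc2F)ccn1` — 1780 nM

In a functional assay on NCI-H460 cells (Homo sapiens) for cytotoxicity, read by MTT assay, with a stated time of 72 h (a lower number here means a stronger inhibitor, a higher number a weaker inhibitor), compound 2 has the lowest of the two numbers; compound 1 sits next with a higher one, since a 2.5-fold lower number from compound 1 to compound 2 (0.39 log units; beyond the scatter). Compound 3, `COc1cc(/C=N/NC(=O)Nc2ccc(Oc3ccnc(-c4nncn4CCN(C)C)c3)c(F)c2)ccc1O`, has not been measured. It differs from compound 2 in one place: 4-hydroxy-3-methoxyphenyl in place of 2-chloro-4-fluorophenyl on a carbon with a double bond to nitrogen. Among the measured compounds shown here, the only step that bears on this is the step from compound 1 to compound 2, where a 4-hydroxyphenyl became a 2-chloro-4-fluorophenyl and the number fell modestly. Compound 3 returns to a 4-hydroxyphenyl with an added methoxy group, so a step in the opposite direction is expected, roughly undoing that gain: a 2.1-fold higher number from compound 2 to compound 3 (0.32 log units; beyond the scatter). Compound 3 is therefore estimated at 1500 nM, within 600 nM to 4000 nM.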

Compound 3, half-maximal inhibitory concentration: 57 nM
Compound 3: middle estimate off by 26-fold (1.42 log units), on the high side; the whole stated range lies above it.
By their numbers in this assay, from the lowest: compound 3; then compound 2; then compound 1.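

On a carbon with a double bond to nitrogen, the choice of aromatic ring matters far more than the earlier pair showed: in this assay, 4-hydroxy-3-methoxyphenyl in place of 2-chloro-4-fluorophenyl gives a 13-fold lower number from compound 2 to compound 3 (1.10 log units; beyond the scatter). Methoxy in place of hydrogen on an aromatic carbon of the 4-hydroxyphenyl ring gives a 31-fold lower number from compound 1 to compound 3 (1.49 log units; beyond the scatter), so this one small addition separates two otherwise identical compounds. Nothing measured here explains why the methoxy has so large an effect. From the compounds shown here alone, it remains open whether a larger ethoxy group would keep the low number. An amine in place of the methoxy is equally untested in the compounds shown here.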